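Sulfamide in place of an acetamide on a furazan amidoxime

The source may report more compounds than this note shows. Statements on the series, on what has been measured and on what is new or still open speak of the compounds shown alone.

Measured compounds:
compound 1, `COc1nonc1/C(=N/O)Nc1ccc(F)c(Br)c1`, 39 nM
compound 2, `NS(=O)(=O)CC(=O)NCCSc1nonc1/C(=N/O)Nc1ccc(F)c(Br)c1`, 12 nM

Of the compounds shown here, two have been tested in an assay for inhibition of Indoleamine 2,3-dioxygenase 1 (Homo sapiens), read by fluorescence, with a stated time of 24 h; a lower number here means a stronger inhibitor, a higher number a weaker inhibitor. Compound 1 gives 39 nM. Compound 2 gives 12 nM, the lower of the two numbers, and its gap to compound 1 lies beyond the scatter of repeated measurements. From the compounds shown here alone, compound 3, `NS(=O)(=O)NCCSc1nonc1/C(=N/O)Nc1ccc(F)c(Br)c1`, remains untested. It differs from compound 2 in one place: sulfamoyl in place of (sulfamoylmethyl)carbonyl on an amine nitrogen. Within the data shown here, since no pair of measured compounds spans this change, the size of the step cannot be read from the numbers at hand. The shared core and the aryl group are kept, and the chain is shortened by the carbonylmethyl unit. The author expects compound 3 to stay close to compound 2 in this assay, with a step from compound 2 to compound 3 of a 1.2-fold lower number from compound 2 to compound 3 (0.08 log units; within the scatter) that would lie within the scatter. The estimated value for compound 3 is 10 nM, with a range from 3 nM to 35 nM.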

Compound 3, half-maximal inhibitory concentration: 2.8 nM
Compound 3: middle estimate off by 3.6-fold (0.55 log units), on the high side; measured number below the stated range.
By their numbers in this assay, from the lowest: compound 3; then compound 2; then compound 1.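

In this assay, the group on the amine nitrogen proves to matter: sulfamoyl in place of (sulfamoylmethyl)carbonyl gives a 4.3-fold lower number from compound 2 to compound 3 (0.63 log units; beyond the scatter), so the smaller group is not merely tolerated at this position but goes with a lower number. Set against the methoxy on the aromatic carbon of compound 1, the (2-(sulfamoylamino)ethyl)sulfanyl group gives a 14-fold lower number from compound 1 to compound 3 (1.14 log units; beyond the scatter), the widest gap among the steps at hand.

The step from compound 2 leaves open whether the sulfamoyl group itself or the loss of the carbonyl and methylene unit accounts for the change, and an acetyl, a methanesulfonyl or a carboxylic acid in place of sulfamoyl, or a longer chain, would help separate these readings. No measurement available here explains why the number falls with either change.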